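This account rests on a few compounds, and the source may have more. Where it says the series, first, only, none or still open, it means among the compounds named here.

In a functional assay on MCF7 cells (Homo sapiens) for antiproliferative activity (a lower number here means a stronger inhibitor, a higher number a weaker inhibitor), three amides built on one shared core have been measured. Compound 1 `C#CCOc1ccc(C(=O)Nc2cc3ccc(OC4CCN(C)CC4)c(C)c3oc2=O)cc1CC=C(C)C` gives 1120 nM, and compound 2 `CC(C)=CCc1cccc(C(=O)Nc2cc3ccc(OC4CCN(C)CC4)c(C)c3oc2=O)c1` gives 2100 nM. Compound 3 `Cc1c(OC2CCN(C)CC2)ccc2cc(NC(=O)c3ccccc3)c(=O)oc12`, with an unsubstituted phenyl, gives 11700 nM, the highest number of the three and so the weakest inhibitor of this small set.

Compound 4 `Cc1c(OC2CCN(C)CC2)ccc2cc(NC(=O)c3ccc(O)cc3)c(=O)oc12` departs from compound 3 by one change: hydroxy in place of hydrogen on an aromatic carbon. This puts hydroxy in place of hydrogen on an aromatic carbon, para to a large group.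

Within the data shown here, two measured steps bear on this change, though neither involves a hydroxy group. The closer one is a 5.6-fold higher number from compound 2 to compound 3 (0.75 log units; beyond the scatter), which shows that the 3-methylbut-2-en-1-yl group is worth a modest amount when it gives way to hydrogen. The other is a 1.9-fold higher number from compound 1 to compound 2 (0.27 log units; within the scatter), where losing propargyloxy leaves no difference beyond the scatter. So one substituent on this ring mattered and the other did not, and no measured compound shows what hydroxy itself does.

The expected result is therefore small, a 1.3-fold lower number from compound 3 to compound 4 (0.11 log units; within the scatter), leaning toward a lower number but not expected to exceed the scatter. For compound 4 the estimated value is 9000 nM, with an expected range of 3500 nM to 23000 nM.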

Compound 4, half-maximal inhibitory concentration: 1430 nM
For compound 4 the middle estimate is 6.3-fold (0.80 log units) above the measured one; the measured number lies below the stated range.
By their numbers in this assay, from the lowest: compounds 1, 4 and 2 (each within the scatter of the next); then compound 3.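

In this assay, among these compounds, the single added hydroxy, para to a large group on the benzamide phenyl ring, gives an 8.2-fold lower number from compound 3 to compound 4 (0.91 log units; beyond the scatter) and so shows that this position responds strongly to a group of only 1 heavy atom, something the earlier steps, which involved 3-methylbut-2-en-1-yl and propargyloxy, could not reveal. Replacing the whole aryl group gives a 1.5-fold lower number from compound 2 to compound 4 (0.17 log units; within the scatter), so 4-hydroxyphenyl and 3-(3-methylbut-2-en-1-yl)phenyl cannot be told apart on this amide, even though each differs clearly from the unsubstituted phenyl of compound 3. Nothing in the available data accounts for the size of the hydroxy step.

The compounds shown leave open whether a methoxy group, an amine or a carboxylic acid at this same place would give a step of similar size, and thus whether hydroxy itself is needed. Also open, going by these compounds, is whether hydroxy and 3-methylbut-2-en-1-yl, carried together on one phenyl ring, would add to each other or give no more than either group alone.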